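This account rests on a few compounds, and the source may have more. Where it says the series, first, only, none or still open, it means among the compounds named here.

Measured compounds:
Compound 1, `OCCC(NC1CCN(CCCc2c[nH]c3ccc(-n4cnnc4)cc23)CC1)c1ccccc1`: 100%
Compound 2, `C[C@@H](NC1CCN(CCCc2c[nH]c3ccc(-n4cnnc4)cc23)CC1)c1ccccc1`: 90%
Compound 3, `NC(=O)OC[C@H](NC1CCN(CCCc2c[nH]c3ccc(-n4cnnc4)cc23)CC1)c1ccccc1`: 73%

In a functional assay on CHO cells for activation of 5-hydroxytryptamine receptor 1D (Homo sapiens), read by GTPgammaS binding (a higher number here means a larger maximal response, a lower number a smaller maximal response), compound 2 holds the second highest of the three numbers; against compound 1 the step is a number 10 percentage points lower from compound 1 to compound 2 (within the scatter), against compound 3 it is a number 17 percentage points lower from compound 2 to compound 3 (beyond the scatter). Compound 4, `CN(Cc1ccsc1)C1CCN(CCCc2c[nH]c3ccc(-n4cnnc4)cc23)CC1`, is not yet measured. Its change from compound 2: methyl((thiophen-3-yl)methyl)amino in place of (1-phenylethyl)amino on a saturated ring carbon. All measured steps alter the substituent on the same amine nitrogen while retaining the six-membered aromatic ring and the stereocentre: a number 10 percentage points lower from compound 1 to compound 2 (within the scatter), a number 27 percentage points lower from compound 1 to compound 3 (beyond the scatter), a number 17 percentage points lower from compound 2 to compound 3 (beyond the scatter). None of them exchanges the aromatic ring, so they bear only loosely on this change. Since they show at most modest losses, the step expected in this assay is a small to modest decrease, a number 10 percentage points lower from compound 2 to compound 4 (within the scatter). Compound 4 is estimated at 80% with a range of 55% to 100%.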

Compound 4, largest response reached (reported as efficacy), in percent of the reference or control that the assay uses: 93%
Beside the measured number, compound 4's estimate is 13 percentage points below it; the measured number falls inside the stated range.
By their numbers in this assay, from the lowest: compound 3; then compounds 2, 4 and 1 (each within the scatter of the next).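

In this assay, methyl((thiophen-3-yl)methyl)amino on the saturated ring carbon gives a number 3 percentage points higher from compound 2 to compound 4 (within the scatter) and, against the hydroxylated side chain, a number 7 percentage points lower from compound 1 to compound 4 (within the scatter) as the comparison. A high maximal response at this position therefore needs neither the six-membered aromatic ring of carbon, nor a defined stereocentre, nor the hydrogen-bond donor on that amine nitrogen. Nothing measured explains this tolerance. As far as these compounds go, the thiophene, the methyl and the lost stereocentre change together, so their separate contributions remain open. Also open, from the compounds shown here alone, is whether a pyridinylmethyl group or a carboxylic acid on that nitrogen retains the response.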